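The source may report more compounds than this note shows. Statements on the series, on what has been measured and on what is new or still open speak of the compounds shown alone.

Compound 1 `COc1ccc(CSc2nc(Cc3cccc(Br)c3)c(C)c(=O)[nH]2)cc1` gives > 290000 nM in an ADME assay on MT4 cells (Homo sapiens) for cytotoxicity, read by MTT assay (a higher number here means that more compound is tolerated, a lower number that less compound is tolerated), and that value is a limit of the assay rather than a number.
Compound 2 `CCc1c(Cc2cccc(Br)c2)nc(SCc2ccc(OC)cc2)[nH]c1=O` gives 201000 nM in this assay.
Compound 3 `CCc1c(Cc2cccc(Br)c2)nc(SCc2ccc([N+](=O)[O-])cc2)[nH]c1=O` gives 187000 nM in this assay.

Compound 2 holds the highest of the two numbers, with compound 3 nearest to it: a 1.1-fold lower number from compound 2 to compound 3 (0.03 log units; within the scatter). Compound 1 sits at a limit, (the limit of > 290000 nM in this assay, at which 1 of the 3 values shown sits), so the step from compound 1 to compound 2 reads only as a floor, an at least 1.4-fold lower number from compound 1 to compound 2 (0.15 log units; that floor lies within the scatter).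

Compound 4 `CCc1c(Cc2cc(C)cc(C)c2)nc(SCc2ccc(OC)cc2)[nH]c1=O` differs from compound 2 in one place: 3,5-dimethylphenyl in place of 3-bromophenyl on a saturated chain carbon bound to an aromatic carbon. Within the data shown here, no measured step exchanges the group at that place. The two steps that exist, from compound 1 to compound 2 and from compound 2 to compound 3, are both small, and one of them changes the ring bound through a sulfur-linked chain while the other changes the core; neither points to a shift beyond the scatter in this assay.

Compound 4 is therefore expected to give about 200000 nM, between 100000 nM and 400000 nM, an estimated step of a 1.0-fold lower number from compound 2 to compound 4 (0.00 log units; within the scatter).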

Compound 4, half-maximal cytotoxic concentration: > 317000 nM
Compound 4 ended at the assay's limit (the forecaster's own chance of this, stated with the estimate: 30%); middle value at least 1.5-fold (0.20 log units) from the limit.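

In this assay, among these compounds, the exchange of 3-bromophenyl for 3,5-dimethylphenyl gives the first reading at this place, on a saturated chain carbon bound to an aromatic carbon: an at least 1.5-fold higher number from compound 2 to compound 4 (0.19 log units; that floor lies within the scatter). Among the compounds shown here, compound 4 sits at a limit of the assay, not at a number: the limit of > 317000 nM in this assay, at which 1 of the 4 values shown sits. Replacing the bromine-bearing ring with the dimethyl-substituted one therefore gives no sign that less compound is tolerated, but the step is only a floor, and how far the true number lies beyond it cannot be told.

The compounds shown leave open how this place would read with a ring carrying an amine or a carboxylic acid. From the compounds shown here alone, it also remains open whether the same exchange would read alike on the core of compound 1, which carries methyl where compound 2 carries ethyl.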